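A few compounds are considered here, and "the series" means these few. Any claim that something is new, unique, unknown or untested is made for them only; others in the source may bear on it.

Working notes on the series. Among the measured compounds shown here, compound 3 `CC1CN(C(N)=S)N=C1c1ccc(F)cc1` is the one member with a number in an in vitro assay on cells for inhibition of Amine oxidase [flavin-containing] A (Homo sapiens), read by Amplex Red, with a stated time of 15 min, tested at 100 uM; on this read-out lower numbers stand for less inhibition and higher numbers for more inhibition at the one concentration tested (going by the name of the read-out): compound 3 gives 40% there. For the measured compounds named here, compound 1 `NC(=S)N1CCC(c2ccc(F)cc2)=N1` is reported in this assay as "not active" (no number reported), and compound 2 `CNC(=S)N1CC(C)C(c2ccc(F)cc2)=N1` likewise as "not active" (no number reported), so neither offers a number to set beside compound 3, and no step between measured compounds can be stated.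

Compound 4 `CC1CN(C(N)=S)N=C1c1ccc(Cl)cc1` has not yet been measured in this assay. It differs from compound 3 by chloro in place of fluoro on an aromatic carbon. With no measured step of this kind in the series, the expectation rests on compound 3 alone; the step from compound 3 to compound 4 is expected to stay within the usual scatter, as a number 5 percentage points higher from compound 3 to compound 4 (within the scatter). Compound 4 is thus estimated at 45% in this assay, in a range from 20% to 70%.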

Compound 4, a percentage reported as inhibition, at one concentration (the size of the read-out at that concentration, not a potency): 40%
For compound 4 the middle estimate is 5 percentage points above the measured one; the measured number falls inside the stated range.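

Chloro in place of fluoro on this aromatic carbon gives no change at the digits printed from compound 3 to compound 4 (within the scatter) in this assay as the first readable step of the series. At the one concentration tested, the two halogens at this position are therefore not told apart, so this carbon carries either one with the same printed reading. No measured evidence bears on the reason for this result.

On these data alone, whether a methoxy group, an amine or a carboxylic acid on the same carbon would read alike stays open. So does the reading with bromo or with hydrogen there.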